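The source may hold more compounds than are shown below. What is called first, only, known or untested is meant among the compounds shown, and "the series" means these compounds.

Measured compounds:
Compound 1 `c1ccc(-c2ccc3c(NCCCNCc4ccco4)ccnc3c2)cc1` gives 5920 nM in an ADME assay on HepG2 cells (Homo sapiens) for cytotoxicity, read by luminescence, CellTiter-Glo and ATP content, with a stated time of 72 h; on this read-out lower numbers stand for an effect already at smaller amounts and higher numbers for an effect only at larger amounts of compound.
Compound 2 `COc1ccc(F)cc1CNCCCNc1ccnc2cc(C3CCCCC3)ccc12` gives 2290 nM in this assay.
Compound 3 `Fc1ccc(-c2ccc3c(NCCCNCc4ccco4)ccnc3c2)cc1` gives 7760 nM in this assay.

Of these three, compound 2 gives the lowest number in this assay. Its nearest neighbour is compound 1, whose number is higher by a gap beyond the usual scatter, and compound 3 lies further still, also beyond the scatter. Compound 1 and compound 3 differ from compound 2 in more than one place, so their values show only where compound 2 stands, not what any single change does.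

Compound 4 `COc1ccc(F)cc1CNCCCNc1ccnc2cc(CCc3ccccc3)ccc12` differs from compound 2 in one place: phenethyl in place of cyclohexyl on an aromatic carbon. Among the measured compounds shown here, the only single-point step measured in this set is a 1.3-fold higher number from compound 1 to compound 3 (0.12 log units; within the scatter), which concerns fluoro in place of hydrogen on a different pair of compounds and says nothing about cyclohexyl against phenethyl. For the measured compounds named here, no measured step bears on the change from compound 2 to compound 4. With nothing to point in either direction, the step is expected to stay within the scatter, a 1.1-fold higher number from compound 2 to compound 4 (0.04 log units; within the scatter). Compound 4 is therefore estimated to give 2500 nM in this assay, with a range from 900 nM to 7000 nM.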

Compound 4, half-maximal effective concentration: 4240 nM
Estimate against measurement, compound 4: 1.7-fold (0.23 log units) below; measured number inside the range.
By their numbers in this assay, from the lowest: compounds 2, 4, 1 and 3 (each within the scatter of the next, the first and the last beyond it).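

In this assay the step for phenethyl in place of cyclohexyl on an aromatic carbon is a 1.9-fold higher number from compound 2 to compound 4 (0.27 log units; within the scatter), so this reading does not separate the two groups. Among the compounds shown here, this is the first single-point reading at this position, which is meta to a fused ring on one side and para to a fused ring on the other, since the only earlier step concerned fluoro in place of hydrogen on a different pair of compounds. It shows that a one-ring group of 6 heavy atoms, non-aromatic, and a group of 8 heavy atoms with an aromatic ring can occupy this place on the same core and side chain without a difference beyond the scatter, and no other kind of measurement is at hand to say what lies behind this result.

From the compounds shown here alone, whether an amine, a carboxylic acid or a longer chain at this aromatic carbon would move the number beyond the scatter stays open. So does whether phenethyl and cyclohexyl would still read alike if the side chain of compound 2 were replaced by that of compound 1.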